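Removing the carboxy group from compound 3

The source may report more compounds than this note shows. Statements on the series, on what has been measured and on what is new or still open speak of the compounds shown alone.

Compound 3 `COc1cc(C(=O)O)ccc1OC[C@H](C)COc1ccc(C(=O)CC(C)(C)C)c(O)c1C` holds the lowest of the two measured numbers in this set; in an assay for positive allosteric modulation of metabotropic glutamate receptor 2 (Rattus norvegicus) (on this read-out higher numbers stand for an effect only at larger amounts of compound and lower numbers for an effect already at smaller amounts), compound 3 gives 28 nM. Compound 2 `COc1ccc(C(=O)O)cc1O[C@@H](C)COc1ccc(C(=O)CC(C)(C)C)c(O)c1C` differs from compound 3 in the arrangement of its acid-bearing ring and of the methyl on the linker; in this assay compound 2 gives 137 nM, a higher number than that of compound 3 and beyond the scatter. Compound 1 `COc1ccc(OCCCCOc2ccc(C(=O)CC(C)(C)C)c(O)c2C)cc1` carries no carboxy group and a longer linker; in this assay compound 1 reaches only a limit of the assay, > 10000 nM. The whole of the evidence on limits is the limit of > 10000 nM in this assay, at which 1 of the 3 values shown sits.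

Compound 4 `COc1ccccc1OC[C@H](C)COc1ccc(C(=O)CC(C)(C)C)c(O)c1C` is the next compound to be measured. It is related to compound 3 by a single change: hydrogen in place of carboxy on an aromatic carbon. Among the compounds with values here, no step between two measured compounds that differ in one place exists, so the size of this step cannot be read off directly. The removal of the carboxy group is expected to move the number upward by a clear margin, well beyond the scatter, with the step from compound 3 to compound 4 estimated as a 54-fold higher number from compound 3 to compound 4 (1.73 log units; beyond the scatter). Compound 1, likewise lacking the carboxy group, sits at the limit of > 10000 nM in this assay, at which 1 of the 3 values shown sits, which supports an upward expectation. For compound 4 the expected value in this assay is 1500 nM, with a range from 200 nM to 10000 nM.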

Compound 4, half-maximal effective concentration: "not active" (no number reported)
Compound 4 has no reported number here; the estimate stays without a comparison.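

Within the data shown here, compound 4 is recorded as not active, without a number, so no step from compound 3 can be read; in this assay compound 3 stays at 28 nM with no numeric partner. The compounds shown leave open how large the change is when hydrogen replaces carboxy on this ring. The only numeric limit in the set stands as: the limit of > 10000 nM in this assay, at which 1 of the 4 values shown sits.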